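Ester variation on the lactone series: outlook for compound 3

The source may report more compounds than this note shows. Statements on the series, on what has been measured and on what is new or still open speak of the compounds shown alone.

Compound 1 `CCCCCCCCCCC[C@@H](C[C@@H]1OC(=O)[C@H]1CCCCCC)OC(=O)[C@@H](N)CC(C)C` and compound 2 `CCCCCCCCCCC[C@@H](C[C@@H]1OC(=O)[C@H]1CCCCCC)OC(=O)CNC(=O)OCc1ccccc1` share one core and differ only in the acyl group of the ester. In an assay on membranes from brain for inhibition of Fatty-acid amide hydrolase 1 (Rattus norvegicus) (a lower number here means a stronger inhibitor, a higher number a weaker inhibitor), compound 1 reaches only the limit of the assay, > 50000 nM. Compound 2 likewise reaches only the limit in this assay, > 50000 nM. The step that the two limits leave unreadable from compound 1 to compound 2 thus cannot be read, since both values sit at the limit of > 50000 nM in this assay, at which 2 of the 2 values shown sit. Compound 3 `CCCCCCCCCCC[C@@H](C[C@@H]1OC(=O)[C@H]1CCCCCC)OC(=O)CCNC=O` keeps the same core and carries (formylamino)methyl in place of (benzyloxycarbonyl)amino on a saturated chain carbon bound to a carbonyl carbon. Going by the values given here, no measured step gives a readable size for an acyl change of this kind; the one step available is unreadable. The expectation for compound 3 in this assay is therefore that it, too, stays at the limit, which amounts to an estimated step that the limit leaves unreadable from compound 2 to compound 3 that is not readable beyond the scatter. Compound 3 is expected to give about 60000 nM, with a range from 15000 nM to 250000 nM.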

Compound 3, half-maximal inhibitory concentration: > 50000 nM
Compound 3 was reported as a limit; the forecaster's own chance of this, stated with the estimate: 80%; the middle value does not contradict the limit.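

No step among compound 1, compound 2 and compound 3 can be read in this assay, since each result is only a limit: the limit of > 50000 nM in this assay, at which 3 of the 3 values shown sit.

The compounds shown leave open whether any acyl group on the shared core gives a measurable value in this assay.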